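Lengthening the hydroxycarbamoyl chain from compound 2 to compound 4

A few compounds are considered here, and "the series" means these few. Any claim that something is new, unique, unknown or untested is made for them only; others in the source may bear on it.

Measured in a functional assay on PC-3 cells (Homo sapiens) for inhibition, read by sulforhodamine B assay, with a stated time of 48 h; a higher number here means a weaker inhibitor, a lower number a stronger inhibitor:
- compound 1 `O=C(Nc1ccc(C(=O)NO)cc1)Nc1ccc(Cl)c(C(F)(F)F)c1` gives 3100 nM
- compound 2 `O=C(CCCC(=O)Nc1ccc(NC(=O)Nc2ccc(Cl)c(C(F)(F)F)c2)cc1)NO` gives > 10000 nM, a limit and not a number
- compound 3 `O=C(Nc1ccc2c(c1)CCCN2c1ccc(C(=O)NO)cc1)Nc1ccc(Cl)c(C(F)(F)F)c1` gives 3000 nM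

Compound 2 stands at a limit and has no numerical value: the limit of > 10000 nM in this assay, at which 1 of the 3 values shown sits. Compound 4 `O=C(CCCCCC(=O)Nc1ccc(NC(=O)Nc2ccc(Cl)c(C(F)(F)F)c2)cc1)NO` carries 2-(hydroxycarbamoyl)ethyl in place of hydroxycarbamoyl on a saturated chain carbon, three bonds along the chain from a carbonyl carbon. The same difference reads 3-(hydroxycarbamoyl)propyl to 5-(hydroxycarbamoyl)pentyl.

Among the measured compounds shown here, one measured step bears on this change. For ((3-(hydroxycarbamoyl)propyl)carbonyl)amino in place of hydroxycarbamoyl on an aromatic carbon, the result is an at least 3.2-fold higher number from compound 1 to compound 2 (0.50 log units; beyond the scatter), and this lies beyond the scatter. For the measured compounds named here, no measured step varies the chain length, which leaves the size of the new step uncertain. A modest step towards a lower number is expected in this assay, and the estimate is an at least 1.6-fold lower number from compound 2 to compound 4 (0.22 log units; that floor lies within the scatter). Compound 4 is expected at 6000 nM, with an estimated range from 2000 nM to 15000 nM.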

Compound 4, half-maximal inhibitory concentration: > 10000 nM
Compound 4 gave a limit, no number; the forecaster's own chance of this, stated with the estimate: 40%; at least 1.6-fold (0.22 log units) between middle value and limit.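

No step can be read from compound 2 to compound 4, since each gives only a limit and no number: the limit of > 10000 nM in this assay, at which 2 of the 4 values shown sit.

The compounds shown leave open whether 5-(hydroxycarbamoyl)pentyl in place of 3-(hydroxycarbamoyl)propyl changes inhibition at all, and how far beyond the limit either compound lies.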